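A few compounds are considered here, and "the series" means these few. Any claim that something is new, unique, unknown or untested is made for them only; others in the source may bear on it.

Three close analogues built on one shared core have been measured in a functional assay on K562 cells (Homo sapiens) for inhibition, read by fluorescence and resazurin assay, with a stated time of 72 h; on this read-out higher numbers stand for weaker inhibition of growth and lower numbers for stronger inhibition of growth. Compound 1 `N[C@H]1CC[C@H](Nc2nc(Nc3ccc(-c4ccoc4)nc3)c3ncn(C4CCCC4)c3n2)CC1` gives 876 nM. Compound 2 `COc1ccccc1-c1ccc(Nc2nc(N[C@H]3CC[C@H](N)CC3)nc3c2ncn3C2CCCC2)cn1` gives 553 nM in this assay. Compound 3 `N[C@H]1CC[C@H](Nc2nc(Nc3ccc(-c4ccccc4O)nc3)c3ncn(C4CCCC4)c3n2)CC1` gives 500 nM in this assay; this is the lowest of the three numbers, yet both gaps to its neighbours stay within the scatter, as shown by a 1.8-fold lower number from compound 1 to compound 3 (0.24 log units; within the scatter) and by a 1.1-fold lower number from compound 2 to compound 3 (0.04 log units; within the scatter). A fourth member, compound 4 `COc1ccc(-c2ccc(Nc3nc(N[C@H]4CC[C@H](N)CC4)nc4c3ncn4C3CCCC3)cn2)cc1`, has not yet been measured. It differs from compound 3 in a single place: 4-methoxyphenyl in place of 2-hydroxyphenyl on an aromatic carbon.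

Two of the measured steps bear on this change. The step of a 1.1-fold lower number from compound 2 to compound 3 (0.04 log units; within the scatter) shows that swapping methyl for hydrogen on the oxygen of this aryl group hardly moved the number, and the step of a 1.6-fold lower number from compound 1 to compound 2 (0.20 log units; within the scatter) shows that a methoxyphenyl in place of furan-3-yl also stayed inside the scatter. Among the compounds with values here, no measured pair contains a 4-methoxyphenyl at this carbon, so that part of the change has no direct precedent. Since every step among compounds 1, 2 and 3 remained within the scatter, the change from compound 3 to compound 4 is expected to come to a 1.2-fold higher number from compound 3 to compound 4 (0.08 log units; within the scatter), nothing beyond the scatter. Compound 4 is therefore estimated to give 600 nM in this assay, within a range from 250 nM to 1500 nM.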

Compound 4, concentration for 50% growth inhibition: 698 nM
Estimate against measurement, compound 4: 1.2-fold (0.07 log units) below; low and high end bracket the measured number.
By their numbers in this assay, from the lowest: compounds 3, 2, 4 and 1 (each within the scatter of the next).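

Compound 4 places a 4-methoxyphenyl on this aromatic carbon, next to the ring nitrogen, for the first time among these compounds, and in this assay the exchange for 2-hydroxyphenyl gives a 1.4-fold higher number from compound 3 to compound 4 (0.14 log units; within the scatter), even though the entering group has no hydrogen-bond donor and the leaving group has one. The two methoxyphenyl groups can now be compared directly, with a 1.3-fold higher number from compound 2 to compound 4 (0.10 log units; within the scatter), and the comparison with furan-3-yl gives a 1.3-fold lower number from compound 1 to compound 4 (0.10 log units; within the scatter). All four groups at this carbon therefore lie within the scatter of one another on this read-out, and nothing available accounts for this.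

The compounds shown leave open whether a group of another kind at this carbon, such as an aminomethyl group, a carboxylic acid or a longer alkyl chain, would give a step beyond the scatter. They also leave open whether these aryl groups would stay as close together if another part of the shared core were changed.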